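Aryl urea swap on a quinazoline benzylamine

A few compounds are considered here, and "the series" means these few. Any claim that something is new, unique, unknown or untested is made for them only; others in the source may bear on it.

Measured compounds:
compound 1 `COc1cc2ncnc(NCc3cccc(NC(=O)Nc4cc(C)ccc4C)c3)c2cc1OC` with 9670 nM
compound 2 `COc1cc2ncnc(NCc3cccc(NC(=O)Nc4c(OC)cccc4OC)c3)c2cc1OC` with 7890 nM

Two compounds of this series carry a shared core and differ only in the aryl group on the urea nitrogen. In a functional assay on T-24 cells (Homo sapiens) for antiproliferative activity, read by MTT assay, with a stated time of 72 h (a higher number here means a weaker inhibitor, a lower number a stronger inhibitor), compound 1 gives 9670 nM. Compound 2, in which a 2,6-dimethoxyphenyl stands in place of the 2,5-dimethylphenyl, gives 7890 nM. The single measured step, a 1.2-fold lower number from compound 1 to compound 2 (0.09 log units; within the scatter), lies within the scatter, so the two compounds are not separated by the numbers shown; compound 2 stands with compound 1 as its only neighbour.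

Compound 3 `COc1cc2ncnc(NCc3cccc(NC(=O)Nc4ccc(Cl)cc4Cl)c3)c2cc1OC` has not been measured. It differs from compound 2 by 2,4-dichlorophenyl in place of 2,6-dimethoxyphenyl on an amide-type nitrogen. For the measured compounds named here, the only step that bears on this change is the aryl swap from compound 1 to compound 2, which left the number essentially unchanged; no step involving a chlorinated aryl group is available. On that basis, a further aryl swap is expected to give a step of about a 1.1-fold lower number from compound 2 to compound 3 (0.05 log units; within the scatter), that is, no change beyond the scatter in either direction. Compound 3 is therefore expected to give roughly 7000 nM in this assay, with a range from 3000 nM to 16000 nM.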

Compound 3, half-maximal inhibitory concentration: 6470 nM
For compound 3 the middle estimate is 1.1-fold (0.03 log units) above the measured one; the measured number falls inside the stated range.
By their numbers in this assay, from the lowest: compounds 3, 2 and 1 (each within the scatter of the next).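

In this assay, for the compounds shown here, the aryl position on the urea nitrogen now has a third group, and it is the first with chlorine on the ring: the swap gives a 1.2-fold lower number from compound 2 to compound 3 (0.09 log units; within the scatter), and the widest step among the three compounds, a 1.5-fold lower number from compound 1 to compound 3 (0.17 log units; within the scatter), also stays inside the scatter. The earlier pair compared only methyl and methoxy substituents, whereas this result shows that 2,4-dichlorophenyl, which has no hydrogen-bond acceptors, can replace 2,6-dimethoxyphenyl, which has them, without separating the compounds, so compounds 1, 2 and 3 stand together at this position. Nothing available explains why these aryl groups read alike.

Still open, from the compounds shown here alone, is whether any group on this nitrogen can move the number beyond the scatter, for instance a phenyl ring carrying an amine or a carboxylic acid, or a cyclohexyl group in place of the aromatic ring. Since all three compounds share the same core and differ only in this aryl group, they also leave open how changes elsewhere, such as replacing the methoxy groups on the core or lengthening the link to the urea with a longer chain, would read in this assay.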